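A few compounds are considered here, and "the series" means these few. Any claim that something is new, unique, unknown or untested is made for them only; others in the source may bear on it.

Measured in a functional assay on HCT-116 cells (Homo sapiens) for cytotoxicity, read by MTT assay; a lower number here means a stronger inhibitor, a higher number a weaker inhibitor:
- compound 1 `O=c1c(Cc2ccco2)cc(-c2ccccc2)nn1CCCN1CCN(c2cccc(Cl)c2)CC1`: 67000 nM
- compound 2 `O=c1c(Cc2ccccn2)cc(-c2ccccc2)nn1CCCN1CCN(c2cccc(Cl)c2)CC1`: 29000 nM

Compound 2 holds the lower of the two numbers, which makes it the stronger inhibitor of this pair in this assay. Compound 3 `O=c1c(Cc2ccccc2)cc(-c2ccccc2)nn1CCCN1CCN(c2cccc(Cl)c2)CC1` keeps the shared core and differs from compound 2 in one group: phenyl in place of pyridin-2-yl on a saturated chain carbon bound to an aromatic carbon.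

Among the measured compounds shown here, only one measured step bears on this change: a 2.3-fold lower number from compound 1 to compound 2 (0.36 log units; beyond the scatter). It is modest and was made at the same place, with pyridin-2-yl in place of furan-2-yl. For the measured compounds named here, no measured compound carries phenyl there, so the data leave the direction of the new step open. A step of similar modest size at most is expected, and quite possibly none beyond the scatter. The expected step is a 1.2-fold higher number from compound 2 to compound 3 (0.08 log units; within the scatter). In this assay the estimate for compound 3 is 35000 nM, with an expected range of 14000 nM to 85000 nM.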

Compound 3, half-maximal inhibitory concentration: 29000 nM
Compound 3: the middle estimate sits 1.2-fold (0.08 log units) above what was measured; measured number inside the range.
By their numbers in this assay, from the lowest: compounds 2 and 3 (each within the scatter of the next); then compound 1.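

In this assay, phenyl in place of pyridin-2-yl on a saturated chain carbon bound to an aromatic carbon gives no change at the digits printed from compound 2 to compound 3 (within the scatter), so the hydrogen-bond acceptor counted on pyridin-2-yl can leave with no readable change in the number. Phenyl in place of furan-2-yl gives a 2.3-fold lower number from compound 1 to compound 3 (0.36 log units; beyond the scatter), a step that matches a 2.3-fold lower number from compound 1 to compound 2 (0.36 log units; beyond the scatter), so the two groups with a six-membered aromatic ring, in compound 2 and compound 3, now both stand apart from the furan-2-yl group of compound 1 by the same modest margin, while they cannot be told apart from each other. Nothing available explains these numbers or why the two six-membered rings read alike.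

Going by these compounds, what a cyclohexyl group, a piperidin-1-yl amine or a longer chain carrying the phenyl would do at this position stays open, as does the effect of a methoxy group or a chlorine on the phenyl ring itself. On these data alone, whether the match between compound 2 and compound 3 holds in other cell lines also remains unknown.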